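Alkyl Variation on the Aromatic Nitrogen: Compound 3

This account rests on a few compounds, and the source may have more. Where it says the series, first, only, none or still open, it means among the compounds named here.

For the measured compounds named here, compound 2 `CC(C)n1cnc2c(NCc3ccc(C(=O)Nc4ccccc4N)cc3)nc(Cl)nc21` gives 76% in a functional assay on HCT-116 cells (Homo sapiens) for antiproliferative activity, read by CCK-8 assay, with a stated time of 72 h, tested at 8 uM (a lower number here means a weaker effect, a higher number a stronger effect of the compound at the concentration tested), the higher of the two numbers measured so far; compound 1 `CCCCn1cnc2c(NCc3ccc(C(=O)Nc4ccccc4N)cc3)nc(Cl)nc21` gives 40.9%. Going by the values given here, the only step measured, a number 35.1 percentage points higher from compound 1 to compound 2 (beyond the scatter), sets isopropyl against butyl. Compound 3 `CCCn1cnc2c(NCc3ccc(C(=O)Nc4ccccc4N)cc3)nc(Cl)nc21` differs from compound 2 by propyl in place of isopropyl on an aromatic nitrogen. No measured step covers propyl itself; the one step shown favored isopropyl over butyl, and propyl is neither. The step of a number 21 percentage points lower from compound 2 to compound 3 (beyond the scatter) is therefore expected as a moderate fall from compound 2, with wide uncertainty. Compound 3 is estimated at 55%, between 30% and 80%.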

Compound 3, a percentage reported as inhibition, at one concentration (the size of the read-out at that concentration, not a potency): 29.6%
Compound 3: middle estimate off by 25.4 percentage points, on the high side; measured number outside the range, below it.
By their numbers in this assay, from the lowest: compound 3; then compound 1; then compound 2.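

In this assay, the change from isopropyl to propyl keeps the same heavy-atom count yet gives a number 46.4 percentage points lower from compound 2 to compound 3 (beyond the scatter) at this position, so the arrangement of the three carbons on the aromatic nitrogen matters here, not their number alone. Among the straight chains, the change from butyl to propyl gives a number 11.3 percentage points lower from compound 1 to compound 3 (beyond the scatter) and does not raise the number, so a shorter chain alone does not reproduce the isopropyl result. No measurement here gives a reason for either step.

From the compounds shown here alone, whether another branched group, such as tert-butyl, or a small ring, such as cyclopropyl, matches isopropyl remains open. Going by these compounds, the effect of ethyl on this nitrogen is also open.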